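Selenium Substituent Size and Growth Inhibition in Airway Cells

This account rests on a few compounds, and the source may have more. Where it says the series, first, only, none or still open, it means among the compounds named here.

Compound 1: `C[Se]c1nc(N)c2ccccc2n1` — 54600 nM
Compound 2: `Nc1nc([SeH])nc2ccccc12` — > 100000 nM

In an ADME assay on BEAS-2B cells (Homo sapiens) for cytotoxicity, read by MTT assay, with a stated time of 72 h (a higher number here means a weaker inhibitor of growth, a lower number a stronger inhibitor of growth), compound 1 (`C[Se]c1nc(N)c2ccccc2n1`) gives 54600 nM. For compound 2 (`Nc1nc([SeH])nc2ccccc12`) the assay reports only a limit, > 100000 nM, so compound 2 stands at the limit of > 100000 nM in this assay, at which 1 of the 2 values shown sits, with no number of its own. Going by the values given here, the single measured step, an at least 1.8-fold higher number from compound 1 to compound 2 (0.26 log units; that floor lies within the scatter), shows that taking a methyl off the selenium weakened growth inhibition. Compound 3 (`CCCCC[Se]c1nc(N)c2ccccc2n1`) differs from compound 2 by pentyl in place of hydrogen on a selenium, a change running the opposite way. On the basis of an at least 1.8-fold higher number from compound 1 to compound 2 (0.26 log units; that floor lies within the scatter), the pentyl on the selenium of compound 3 is expected to bring the number back down, toward or past the value of compound 1, although the exact size cannot be read from a starting point that is itself a limit. Compound 3 is therefore estimated at 40000 nM, with a range from 10000 nM to 100000 nM, an expected step of an at least 2.5-fold lower number from compound 2 to compound 3 (0.39 log units; beyond the scatter).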

Compound 3, concentration for total growth inhibition: > 100000 nM
Compound 3 ended at the assay's limit; the forecaster's own chance of this, stated with the estimate: 20%; at least 2.5-fold (0.39 log units) between middle value and limit.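

In this assay, going by these compounds alone, pentyl on the selenium did not bring the number down to a readable value, so compound 3 joins compound 2 at a limit of the assay rather than at a number: the limit of > 100000 nM in this assay, at which 2 of the 3 values shown sit. The step between these two compounds cannot be read, as both ends are limits, and the one readable comparison gives an at least 1.8-fold higher number from compound 1 to compound 3 (0.26 log units; that floor lies within the scatter). Among the compounds shown, only the methyl on the selenium of compound 1 gives a measured value, and the longer pentyl chain does not give a lower number than that methyl.

Going by these compounds, how far compound 2 and compound 3 lie beyond their limits remains open, and so does whether the number changes at all with chain length on the selenium. An ethyl or a propyl on the selenium, or a pentyl chain ending in an amine or a carboxylic acid, would test this.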